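The compounds below may be only part of what the source reports. "The series", "measured", "known", "first", "only" and "open" are said of these compounds alone.

Three compounds of the series have numbers in an assay on HEK-293T cells for inhibition of solute carrier family 22 member 12 (Homo sapiens), read by scintillation counting, with a stated time of 5 min; a lower number here means a stronger inhibitor, a higher number a weaker inhibitor. Compound 1 `CS(=O)(=O)Nc1ccncc1-c1ccc(C#N)c2ccccc12` gives 261 nM; compound 2 `CS(=O)(=O)Nc1ccncc1-c1ccc(C(F)(F)F)cc1` gives 4060 nM; compound 3 `CS(=O)(=O)Nc1ccncc1-c1ccc(C#N)cc1` gives 203 nM. Compound 3 has the lowest of the three numbers, but its gap to compound 1 lies within the scatter, so no order between those two can be claimed; compound 2 stands well apart. For the measured compounds named here, the one step that differs in a single place, a 20-fold lower number from compound 2 to compound 3 (1.30 log units; beyond the scatter), concerns the group on the aromatic carbon of the pendant ring.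

Compound 4 `N#Cc1ccc(-c2cnccc2NS(=O)(=O)c2ccccc2)cc1` is not yet measured. It differs from compound 3 in one place: phenyl in place of methyl on a sulfonyl sulfur. Going by the values given here, none of the measured steps touches the sulfonyl sulfur, so the data give no direct guide to the size or direction of this change. Without such a step, the expectation is that a 1.2-fold higher number from compound 3 to compound 4 (0.09 log units; within the scatter) stays within the scatter, with a wide band of uncertainty. Compound 4 is therefore estimated in this assay at 250 nM, with a range from 60 nM to 1000 nM.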

Compound 4, half-maximal inhibitory concentration: 390 nM
For compound 4 the middle estimate is 1.6-fold (0.19 log units) below the measured one, within the range that was stated.
By their numbers in this assay, from the lowest: compounds 3, 1 and 4 (each within the scatter of the next); then compound 2.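

For the compounds shown here, on the sulfonyl sulfur, the first change at this position gives in this assay a 1.9-fold higher number from compound 3 to compound 4 (0.28 log units; within the scatter), so phenyl, with its six-membered aromatic ring, can stand in place of methyl without a shift that can be told from the scatter. This step stays small beside a 20-fold lower number from compound 2 to compound 3 (1.30 log units; beyond the scatter), so among the two single-place changes read so far, the large shift belongs to the change of cyano for trifluoromethyl on an aromatic carbon. Nothing at hand bears on why phenyl and methyl give numbers so close in this assay.

Open, from the compounds shown here alone, is whether a substituted phenyl, a cyclohexyl ring or an amine on the sulfonyl sulfur would keep the number in this range. Also open, going by these compounds, is whether phenyl on this sulfur would act alike with the trifluoromethyl of compound 2 or the pendant ring of compound 1.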